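Series notes: carbamate core substituent, thiophene to trifluoromethyl

The compounds below may be only part of what the source reports. "The series", "measured", "known", "first", "only" and "open" are said of these compounds alone.

Measured compounds:
compound 1 `Cc1c(C(C)OC(=O)Nc2ccccc2Cl)oc2ncnn12` — 501 nM
compound 2 `Cc1c(C(C)OC(=O)Nc2cccc(F)c2)oc2ncnn12` — 50.1 nM
compound 3 `Cc1c(C(C)OC(=O)Nc2ccccc2)oc2nc(-c3cccs3)nn12` — 7.94 nM

In a functional assay on CHO cells for antagonist activity at metabotropic glutamate receptor 5 (Homo sapiens), read by calcium flux (a lower number here means a stronger inhibitor, a higher number a weaker inhibitor), compound 3 gives the lowest number of the three; compound 2 sits nearest and compound 1 furthest, both separated from it beyond the scatter. Compound 4 `Cc1c(C(C)OC(=O)Nc2ccccc2)oc2nc(C(F)(F)F)nn12` differs from compound 3 by trifluoromethyl in place of thiophen-2-yl on an aromatic carbon. For the measured compounds named here, the only measured single step, a 10-fold lower number from compound 1 to compound 2 (1.00 log units; beyond the scatter), concerns the phenyl ring on the carbamate nitrogen and does not touch the position changed here, so no measured step bears on this change. Given the modest size of that one step, a moderate move is expected for compound 4 rather than a large one, with a loss of potency the more likely direction; the step from compound 3 is estimated as a 3.1-fold higher number from compound 3 to compound 4 (0.50 log units; beyond the scatter). Compound 4 is therefore expected at 25 nM, range 6 nM to 100 nM.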

Compound 4, half-maximal inhibitory concentration: 39.8 nM
The estimate for compound 4 lay 1.6-fold (0.20 log units) below the measured number, within the range that was stated.
By their numbers in this assay, from the lowest: compound 3; then compounds 4 and 2 (each within the scatter of the next); then compound 1.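

In this assay, the aromatic carbon between two ring nitrogen atoms proves sensitive to its substituent: trifluoromethyl in place of thiophen-2-yl gives a 5.0-fold higher number from compound 3 to compound 4 (0.70 log units; beyond the scatter). For the compounds shown here, this is the first reading at this position, as the earlier step concerned only the phenyl ring on the carbamate nitrogen, and thiophen-2-yl is the better of the two groups. Nothing available explains the difference.

As far as these compounds go, whether a phenyl ring, a methyl group or an amine would match thiophen-2-yl remains open. The hydrogen at this position in compound 1 and compound 2 cannot be compared directly, as their carbamate phenyl rings also differ.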